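A Dimethoxyphenyl Swap on the Shared Core

The compounds below may be only part of what the source reports. "The series", "measured", "known", "first", "only" and "open" are said of these compounds alone.

Going by the values given here, compound 2 `Nc1cc(N)c2nc(-c3ccccc3)c(NCc3ccc(Cl)c(Cl)c3)nc2c1` stands in a functional assay on SK-OV-3 cells (Homo sapiens) for inhibition, read by sulforhodamine B assay, with a stated time of 48 h (on this read-out higher numbers stand for weaker inhibition of growth and lower numbers for stronger inhibition of growth), at 18600 nM, the only plain number among the two values available. Compound 1 `CCOC(=O)[C@H](CCC(=O)O)NC(=O)c1ccc(CNc2nc3cc(N)cc(N)c3nc2-c2ccccc2)cc1` returns only a limit of this assay, < 100000 nM. Compound 3 `COc1ccc(CNc2nc3cc(N)cc(N)c3nc2-c2ccccc2)cc1OC` differs from compound 2 by a single change: 3,4-dimethoxyphenyl in place of 3,4-dichlorophenyl on a saturated chain carbon bound to a nitrogen on an aromatic ring. Among the compounds with values here, no step between two measured compounds is available to set a scale for this change. The expectation is a modest loss of growth inhibition from compound 2 to compound 3, a 1.6-fold higher number from compound 2 to compound 3 (0.21 log units; within the scatter), a step that may still fall within the scatter. Compound 3 is estimated at 30000 nM, between 9000 nM and 100000 nM.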

Compound 3, concentration for 50% growth inhibition: 21900 nM
Compound 3: middle estimate off by 1.4-fold (0.14 log units), on the high side; the measured number falls inside the stated range.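

At this place, on a saturated chain carbon bound to a nitrogen on an aromatic ring, this assay gives a 1.2-fold higher number from compound 2 to compound 3 (0.07 log units; within the scatter) and so cannot tell 3,4-dimethoxyphenyl from 3,4-dichlorophenyl. Going by these compounds alone, this is the first measured step here, and it shows that two hydrogen-bond acceptors can enter on the ring without a reading beyond the scatter. Nothing measured here speaks to why the two groups read alike.

Going by these compounds, whether a nitrile or an amine on that ring would shift the number beyond the scatter remains open.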